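Adding methoxy to a compound at the assay limit

The compounds below may be only part of what the source reports. "The series", "measured", "known", "first", "only" and "open" are said of these compounds alone.

Compound 1 `CCCCNc1nc(N)nc2cccc(C(=O)NC(C)C)c12`: limit, > 25000 nM
Compound 2 `CCCCNc1nc(N)nc2cccc(C(=O)N(C)Cc3ccccc3)c12`: limit, > 25000 nM
Compound 3 `CCCCNc1nc(N)nc2cccc(C(=O)N[C@@H](C)c3ccccc3)c12`: limit, > 25000 nM

These values come from an ADME assay on HEK293 cells (Homo sapiens) for cytotoxicity, with a stated time of 6 h; on this read-out lower numbers stand for higher toxicity in this test and higher numbers for lower toxicity in this test. Each is a limit and not a measured number, so compound 3 has no exact position among the three. The evidence comes down to one point: the limit of > 25000 nM in this assay, at which 3 of the 3 values shown sit.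

Compound 4 `CCCCNc1nc(N)nc2cccc(C(=O)N[C@@H](C)c3cccc(OC)c3)c12` carries methoxy in place of hydrogen on an aromatic carbon, turning phenyl into 3-methoxyphenyl: methoxy in place of hydrogen on an aromatic carbon.

Among the measured compounds shown here, no measured step tests this change directly. The nearest steps alter the group on the amide: a step that the two limits leave unreadable from compound 1 to compound 3 and a step that the two limits leave unreadable from compound 2 to compound 3. Neither has a readable size, so they offer only weak guidance. Still, the limit for compound 3, > 25000 nM, gives no sign of toxicity in this assay, so no clear shift in either direction is expected for compound 4. The expected change is a step that the limit leaves unreadable from compound 3 to compound 4. Compound 4 will most likely report only a limit too. For compound 4, the estimated value is 30000 nM, with an expected range from 12000 nM to 50000 nM.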

Compound 4, half-maximal cytotoxic concentration: > 25000 nM
Compound 4: only a limit was reported; the forecaster's own chance of this, stated with the estimate: 85%; the middle value lies beyond the limit too.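

Compound 3 and compound 4 both report only a limit in this assay, so the step between them cannot be read. The compounds shown leave open at what concentration, if any, toxicity would appear, since all of them share one limit: the limit of > 25000 nM in this assay, at which 4 of the 4 values shown sit.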